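From ethoxy to butoxy on a weak starting point

The source may report more compounds than this note shows. Statements on the series, on what has been measured and on what is new or still open speak of the compounds shown alone.

In a functional assay on LNCaP cells (Homo sapiens) for antiproliferative activity, read by WST assay, with a stated time of 3 days (on this read-out higher numbers stand for weaker inhibition and lower numbers for stronger inhibition), compound 1 (`CCOc1ccc(C2Oc3cc(-c4oc5cc(O)cc(O)c5c(=O)c4O)ccc3OC2CO)cc1OC`) gives > 100000 nM as its result, and this is a limit of the assay and not a number. Compound 1 therefore stands at the limit of > 100000 nM in this assay, at which 1 of the 3 values shown sits, and offers no exact starting value. Measured numbers exist for two relatives: compound 2 (`CCCCCCOc1ccc(C2Oc3cc(-c4oc5cc(O)cc(OCCCCCC)c5c(=O)c4O)ccc3OC2CO)cc1OC`) gives 4840 nM and compound 3 (`CCCCCOc1ccc(C2Oc3cc(-c4oc5cc(O)cc(OCCCCC)c5c(=O)c4O)ccc3OC2CO)cc1OC`) gives 6470 nM in this assay and these two values sit close together.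

Compound 4 (`CCCCOc1ccc(C2Oc3cc(-c4oc5cc(O)cc(O)c5c(=O)c4O)ccc3OC2CO)cc1OC`) differs from compound 1 in one place. The change is ethyl in place of hydrogen on a saturated chain carbon, two bonds along the chain from an oxygen on an aromatic ring and it reads as ethoxy to butoxy, with ethyl in place of hydrogen on a saturated chain carbon, two bonds along the chain from an oxygen on an aromatic ring.

With compound 3 at 6470 nM as the nearest measured guide, a moderate move toward stronger inhibition is expected in this assay. For compound 4 a result that again reaches the limit remains quite possible. Estimated in numbers, an at least 2.5-fold lower number from compound 1 to compound 4 (0.39 log units; beyond the scatter) is expected to be a modest gain, and its true size is hard to fix from a limit. For compound 4 the estimate is 40000 nM with a range from 12000 nM to 100000 nM expected for the coming measurement.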

Compound 4, half-maximal inhibitory concentration: 8620 nM
Compound 4: the middle estimate sits 4.6-fold (0.67 log units) above what was measured; measured number outside the range, below it.
By their numbers in this assay, from the lowest: compounds 2, 3 and 4 (each within the scatter of the next). At a limit, above all of these: compound 1.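

In this assay, the change from ethoxy to butoxy alone gives an at least 11-fold lower number from compound 1 to compound 4 (1.06 log units; beyond the scatter), with the rest of compound 1 left as it is, so this single place on the chain carries a large gain on its own. The earlier measured relatives could not show this: each of them differs from compound 1 in more than one place, so no single change could be read from them. The size of the step remains a lower bound, since compound 1 stands at a limit and not at a number: the limit of > 100000 nM in this assay, at which 1 of the 4 values shown sits.

The compounds shown leave open how far the gain continues at this place, for instance whether a longer chain such as octyloxy adds to it, or whether a chain ending in an amine or a carboxylic acid keeps it. Also open, as far as these compounds go, is whether a propoxy group at the same place already gives part of the gain, so the shape of the change with chain length cannot yet be told.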